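Swapping the piperazine substituent: from methoxyphenyl to methyl

The source may report more compounds than this note shows. Statements on the series, on what has been measured and on what is new or still open speak of the compounds shown alone.

Measured compounds:
compound 1 `COc1ccc(N2CCN(C(=S)SCc3ccc(C(=O)Nc4ccccc4N)cc3)CC2)cc1`, 28.1%
compound 2 `Nc1ccccc1NC(=O)c1ccc(CSC(=S)N2CCc3cc(Cl)ccc32)cc1`, 31.9%
compound 3 `Nc1ccccc1NC(=O)c1ccc(CSC(=S)N2CCN(Cc3ccncc3)CC2)cc1`, 33.1%

In a functional assay on A-375 cells (Homo sapiens) for antiproliferative activity, read by CCK-8 assay, with a stated time of 72 h, tested at 2 uM (on this read-out lower numbers stand for a weaker effect and higher numbers for a stronger effect at the one concentration tested), compound 1 gives 28.1%, the lowest of the three numbers, yet its gaps to compound 2 and to compound 3 both lie within the usual scatter, so none of the three can be set apart from the others. Compound 4 `CN1CCN(C(=S)SCc2ccc(C(=O)Nc3ccccc3N)cc2)CC1` has not yet been measured. It differs from compound 1 in one place: methyl in place of 4-methoxyphenyl on an amine nitrogen in a ring. For the measured compounds named here, the only measured step that touches the same position is the one from compound 1 to compound 3, where the same 4-methoxyphenyl was exchanged; that step gave a number 5 percentage points higher from compound 1 to compound 3 (within the scatter). Going by the values given here, nothing among the measured compounds shows that what sits on this ring nitrogen shifts the read-out beyond the scatter, so the step to compound 4 is expected to be a number 0.9 percentage points higher from compound 1 to compound 4 (within the scatter), neither clearly up nor down. Compound 4 is therefore estimated at 29%, in a range from 17% to 41%.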

Compound 4, a percentage reported as inhibition, at one concentration (the size of the read-out at that concentration, not a potency): 36.6%
Beside the measured number, compound 4's estimate is 7.6 percentage points below it; measured number inside the range.
By their numbers in this assay, from the lowest: compounds 1, 2, 3 and 4 (each within the scatter of the next).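

Compound 4 shows that in this assay the 4-methoxyphenyl group on the amine nitrogen in a ring can give way to a bare methyl without the number leaving the scatter (the step is a number 8.5 percentage points higher from compound 1 to compound 4 (within the scatter)). The same holds against the two other compounds, for the loss of pyridin-4-yl on the saturated chain carbon (a number 3.5 percentage points higher from compound 3 to compound 4 (within the scatter)) and for 4-methylpiperazin-1-yl in place of 5-chloro-2,3-dihydro-1H-indol-1-yl on the thiocarbonyl carbon (a number 4.7 percentage points higher from compound 2 to compound 4 (within the scatter)). No measurement to hand explains this flat picture.

The compounds shown leave open whether a plain hydrogen on that ring nitrogen, a longer alkyl chain or a chain ending in a carboxylic acid would move the read-out beyond the scatter. With one concentration only, they also leave open whether these compounds differ in potency.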